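The source may hold more compounds than are shown below. What is called first, only, known or untested is meant among the compounds shown, and "the series" means these compounds.

Compound 1 `Cc1ccc(NC(=O)C2CCN(C/C=C/c3ccccc3)CC2)cc1` is one of three compounds that share a core and differ only in the aromatic group on the amide-type nitrogen. In a functional assay on MGC-803 cells (Homo sapiens) for inhibition, read by MTT assay, with a stated time of 72 h (a higher number here means a weaker inhibitor, a lower number a stronger inhibitor), compound 1 gives 24100 nM, the second highest of the three numbers. Compound 2 `CC(C)c1ccc(NC(=O)C2CCN(C/C=C/c3ccccc3)CC2)cc1` gives 5200 nM, and the change a 4.6-fold lower number from compound 1 to compound 2 (0.67 log units; beyond the scatter). Compound 3 `COc1cccc(NC(=O)C2CCN(C/C=C/c3ccccc3)CC2)c1` gives 37200 nM, and the change a 1.5-fold higher number from compound 1 to compound 3 (0.19 log units; within the scatter). Between the two, a 7.2-fold higher number from compound 2 to compound 3 (0.85 log units; beyond the scatter).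

Compound 4 `O=C(Nc1ccccn1)C1CCN(C/C=C/c2ccccc2)CC1` is not yet measured. Relative to compound 1 it carries pyridin-2-yl in place of 4-methylphenyl on an amide-type nitrogen. Within the data shown here, of the measured steps, only the step from compound 1 to compound 3 also swaps one aromatic group for another on that nitrogen, and it stayed within the scatter; the step from compound 1 to compound 2 enlarges a group rather than replacing the ring, so it bears less on this change. Among the measured compounds shown here, no measured step brings a ring nitrogen into this position. The expectation is therefore a small step at most, probably towards a higher number, a 1.5-fold higher number from compound 1 to compound 4 (0.16 log units; within the scatter). Compound 4 is thus estimated at 35000 nM, with a range from 12000 nM to 100000 nM.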

Compound 4, half-maximal inhibitory concentration: 45200 nM
Beside the measured number, compound 4's estimate is 1.3-fold (0.11 log units) below it; the measured number falls inside the stated range.
By their numbers in this assay, from the lowest: compound 2; then compounds 1, 3 and 4 (each within the scatter of the next).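

In this assay, putting pyridin-2-yl on the amide-type nitrogen brings a ring nitrogen and a hydrogen-bond acceptor into this group, yet the result stays within the scatter of both earlier comparators (a 1.9-fold higher number from compound 1 to compound 4 (0.27 log units; within the scatter); a 1.2-fold higher number from compound 3 to compound 4 (0.08 log units; within the scatter)). Compounds 1, 3 and 4 therefore cannot be told apart here, and only compound 2, with its 4-isopropylphenyl group, stands apart from compound 4 (an 8.7-fold higher number from compound 2 to compound 4 (0.94 log units; beyond the scatter)). No measured information is available to explain these numbers.

The compounds shown leave open whether pyridin-3-yl would behave like pyridin-2-yl. Going by these compounds, it is also open whether a tert-butyl group, an amine or a carboxylic acid on the aromatic ring would match or move away from the number of compound 2.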